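Halogen Added to the Hydroxy-Bearing Ring of Compound 1

The source may hold more compounds than are shown below. What is called first, only, known or untested is meant among the compounds shown, and "the series" means these compounds.

Measured compounds:
compound 1 `O=C(c1cccnc1)c1ccccc1O` — 24600 nM
compound 2 `C=CCOc1c(Cl)cc(Cl)cc1C(=O)c1cccnc1` — 85000 nM
compound 3 `O=C(c1cccnc1)c1ccc(Br)cc1O` — a limit only

In a functional assay on MCF7 cells (Homo sapiens) for cytotoxicity, read by sulforhodamine B assay, with a stated time of 48 h (a lower number here means a stronger inhibitor, a higher number a weaker inhibitor), compound 1 gives 24600 nM, the lowest of the two numbers shown. Compound 2 gives 85000 nM, a higher number beyond the scatter. Compound 3 gives only a limit of the assay, > 100000 nM, so its exact value is not known (the limit of > 100000 nM in this assay, at which 1 of the 3 values shown sits).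

Compound 4 `O=C(c1cccnc1)c1cccc(Cl)c1O` differs from compound 1 in one place: chloro in place of hydrogen on an aromatic carbon. For the measured compounds named here, the one measured step that resembles this change is the addition of a halogen to the same ring, where the number rose an at least 4.0-fold higher number from compound 1 to compound 3 (0.60 log units; beyond the scatter). On that basis a rise in this assay is expected for compound 4 too, though a chloro is a smaller group than a bromo and sits at a different carbon, so a smaller step is anticipated, a 2.0-fold higher number from compound 1 to compound 4 (0.31 log units; beyond the scatter). Compound 4 is therefore expected to give about 50000 nM, with a likely range from 20000 nM to 150000 nM, and some chance that only a limit is reported.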

Compound 4, half-maximal inhibitory concentration: 26700 nM
Compound 4: the middle estimate sits 1.9-fold (0.27 log units) above what was measured; the range from low to high includes it.
By their numbers in this assay, from the lowest: compounds 1 and 4 (each within the scatter of the next); then compound 2. At a limit, above all of these: compound 3.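

In this assay a chloro ortho to the hydroxy group gives a 1.1-fold higher number from compound 1 to compound 4 (0.04 log units; within the scatter) and so leaves compound 1 and compound 4 indistinguishable. A halogen on this ring is thus not always followed by a higher number, as the earlier bromo step of an at least 4.0-fold higher number from compound 1 to compound 3 (0.60 log units; beyond the scatter) alone might have suggested. Those two steps differ in both the halogen and the carbon it sits on, so they cannot show which of the two matters.

As far as these compounds go, whether a bromo, an amine or a carboxylic acid on this same carbon would also match compound 1 remains open. How far compound 3 lies from the other compounds also remains unknown, because its value is only a limit: the limit of > 100000 nM in this assay, at which 1 of the 4 values shown sits.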